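A Benzyl Group in Place of a Hydroxymethyl-Bearing Ring

A few compounds are considered here, and "the series" means these few. Any claim that something is new, unique, unknown or untested is made for them only; others in the source may bear on it.

Compound 1 `C=CCn1c(=O)n(C2CCC(CO)C2)c2nc(N)nc(O)c21`, compound 2 `C=CCn1c(=O)n(C2C[C@H](O)C(CO)O2)c2nc(N)nc(O)c21` and compound 3 `C=CCn1c(=S)n(C2OC(COC(C)=O)[C@H]3OC(C)(C)O[C@@H]23)c2nc(N)nc(O)c21` share one core and were tested in a functional assay (B cells) with Mus musculus as the target; a lower number here means that less compound is needed, a higher number that more compound is needed for the effect. Compound 1 gives 226 uM, the highest number of the three, so the most compound is needed for the effect. Compound 2 gives 30 uM and compound 3 gives 50 uM, both lower than compound 1 by more than the usual scatter. Compound 4 `C=CCn1c(=O)n(Cc2ccccc2)c2nc(N)nc(O)c21` differs from compound 1 in one place: a group of 7 heavy atoms (7 carbon; one six-membered aromatic ring of carbon only) in place of a group of 7 heavy atoms (6 carbon, 1 oxygen; one five-membered non-aromatic ring of carbon only), on an aromatic nitrogen. Among the compounds with values here, no measured pair shows a change of this kind alone, so its size is unknown. The expected step of a 1.3-fold higher number from compound 1 to compound 4 (0.12 log units; within the scatter) is small, either none beyond the scatter or a slight rise. Compound 4 is therefore expected to give about 300 uM, between 80 uM and 1000 uM.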

Compound 4, concentration for half-maximal effect: 5 uM
For compound 4 the middle estimate is 60-fold (1.78 log units) above the measured one; measured number below the stated range.
By their numbers in this assay, from the lowest: compound 4; then compounds 2 and 3 (each within the scatter of the next); then compound 1.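

In this assay, benzyl on this aromatic nitrogen, in place of the group with the five-membered non-aromatic ring, gives a 45-fold lower number from compound 1 to compound 4 (1.66 log units; beyond the scatter) and is a large step. A group with 0 hydrogen-bond donors and 0 hydrogen-bond acceptors therefore serves at this position, so the donor and acceptor of the group that leaves are not needed for a low number. Nothing measured here explains the size of this step. On these data alone, whether the aromatic ring itself matters remains open, and a cyclohexylmethyl group would test that. Also open, as far as these compounds go, is how a longer chain such as phenethyl, or a carboxylic acid on the benzyl ring, would fare.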